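The source may report more compounds than this note shows. Statements on the series, on what has been measured and on what is new or still open speak of the compounds shown alone.

Three compounds built on one shared core have been checked for how much of each MT4 cells tolerate. In an ADME assay on MT4 cells (Homo sapiens) for cytotoxicity, read by MTT assay (a higher number here means that more compound is tolerated, a lower number that less compound is tolerated), compound 1 `COC(=O)c1ccc(NC(=O)CSc2nncnc2-c2ccccc2Cl)c(Br)c1` gives 59000 nM, compound 3 `O=C(CSc1nncnc1-c1cccc2ccccc12)Nc1ccccc1` gives 154000 nM, and compound 2 `O=C(CSc1nncnc1-c1ccccc1Cl)Nc1ccccn1` gives 172000 nM. The numbers for compound 2 and compound 3 lie within the usual scatter of each other, while compound 2 stands beyond the scatter above compound 1. Compound 4 `O=C(CSc1nncnc1-c1ccccc1Cl)Nc1cccnc1Cl` has not yet been measured. It differs from compound 2 in one place: 2-chloropyridin-3-yl in place of pyridin-2-yl on an amide-type nitrogen. Going by the values given here, no measured pair shows a comparable change, so the data give no direction for it. The step is expected to stay small, a 1.3-fold lower number from compound 2 to compound 4 (0.12 log units; within the scatter), not beyond the scatter. In this assay compound 4 is therefore expected to give 130000 nM, within 55000 nM to 260000 nM.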

Compound 4, half-maximal cytotoxic concentration: 167000 nM
For compound 4 the middle estimate is 1.3-fold (0.11 log units) below the measured one; low and high end bracket the measured number.
By their numbers in this assay, from the lowest: compound 1; then compounds 3, 4 and 2 (each within the scatter of the next).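

In this assay, putting 2-chloropyridin-3-yl in place of pyridin-2-yl on the amide-type nitrogen gives a 1.0-fold lower number from compound 2 to compound 4 (0.01 log units; within the scatter). Going by these compounds alone, this is the first direct reading of a change at this position, and the cells tolerate the chlorine-bearing ring as well as the plain one. No available evidence bears on a cause for this result.

As far as these compounds go, whether a ring carrying an amine or a carboxylic acid, or an ethyl chain in place of the ring, would also leave the number in place stays open. This single step also cannot separate the contribution of the chlorine from that of the changed ring attachment.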